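This account rests on a few compounds, and the source may have more. Where it says the series, first, only, none or still open, it means among the compounds named here.

Measured so far:
- compound 1 `CCCCCCCCCCCCNC[C@@H]1OC[C@H](N)[C@H]1O`, a functional assay on B16-F10 cells (Mus musculus) for antiproliferative activity, read by MTT assay, with a stated time of 72 h; a higher number here means a weaker inhibitor, a lower number a stronger inhibitor: 58100 nM
- compound 2 `CCCCCCCNC[C@@H]1OC[C@H](N)[C@H]1O`, this assay: > 128000 nM
- compound 3 `CCCCCCCCCNC[C@@H]1OC[C@H](N)[C@@H]1O`, this assay: 55200 nM

The value of compound 2 is a limit of the assay and not a number; it stands at the limit of > 128000 nM in this assay, at which 1 of the 3 values shown sits.

Between compound 2 and compound 1 the change is pentyl in place of hydrogen on a saturated chain carbon, seven bonds along the chain from an amine nitrogen. The step it made is an at least 2.2-fold lower number from compound 2 to compound 1 (0.34 log units; beyond the scatter).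

Compound 3 and compound 1 sit within the usual scatter of each other in this assay, so no order is read between them. How the core of compound 3 differs from the core of compound 2 is not broken down here.

Compound 4 `CCCCCCCCCCCCCCNC[C@@H]1OC[C@H](N)[C@@H]1O` is not yet measured. From compound 3 it differs by pentyl in place of hydrogen on a saturated chain carbon, nine bonds along the chain from an amine nitrogen. This is the same kind of change as that from compound 2 to compound 1, but here it sits nine bonds along the chain from the amine nitrogen rather than seven. The step expected from this change is a 2.2-fold lower number from compound 3 to compound 4 (0.34 log units; beyond the scatter); that expectation rests on the earlier step of an at least 2.2-fold lower number from compound 2 to compound 1 (0.34 log units; beyond the scatter) and on the value of compound 3, 55200 nM. In this assay compound 4 is expected to give about 25000 nM, most likely between 9000 nM and 70000 nM.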

Compound 4, half-maximal inhibitory concentration: 14300 nM
For compound 4 the middle estimate is 1.7-fold (0.24 log units) above the measured one; low and high end bracket the measured number.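

In this assay, pentyl in place of hydrogen on a saturated chain carbon, nine bonds along the chain from an amine nitrogen, gives a 3.9-fold lower number from compound 3 to compound 4 (0.59 log units; beyond the scatter), so on the core of compound 3 the change runs in the same direction as on the core of compound 1. Compound 2 gives > 128000 nM, which is a limit of the assay and not a number. The direction therefore carries across these two cores, but this does not show that the size carries, and two pairs say nothing about any further core: the same change on two cores in this assay, an at least 2.2-fold lower number (0.34 log units; beyond the scatter) from compound 2 to compound 1 and a 3.9-fold lower number (0.59 log units; beyond the scatter) from compound 3 to compound 4; the limit leaves it open whether they differ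

The compounds shown hold no pair with the same chain on both cores, so how the two cores compare at a fixed chain length remains open. Also open, going by these compounds, is whether the number keeps falling with a longer chain than that of compound 4, and how a chain ending in an amine or a carboxylic acid would read.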